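The compounds below may be only part of what the source reports. "The series", "measured", "known", "first", "only" and "open" are said of these compounds alone.

Compound 2 `COc1ccc(CN(C(=O)C(C)Br)c2cc(OC)c(OC)c(OC)c2)cc1O` gives 140 nM in a functional assay on HCT-116 cells (Homo sapiens) for inhibition, read by MTT assay, with a stated time of 48 h (a higher number here means a weaker inhibitor, a lower number a stronger inhibitor), the lowest of the two numbers measured. Compound 3 `COc1ccc(N(Cc2cc(OC)c(OC)c(OC)c2)C(=O)CN=[N+]=[N-])cc1O` gives 38800 nM in this assay, a gap from compound 2 that lies beyond the scatter. In this assay compound 1 `COc1cc(NCc2ccccc2)cc(OC)c1OC` gives > 80000 nM, which is a limit rather than a number; this is the limit of > 80000 nM in this assay, at which 1 of the 3 values shown sits. Compound 4 `C/C=C/C(=O)N(Cc1ccc(OC)c(O)c1)c1cc(OC)c(OC)c(OC)c1` has not yet been measured. It differs from compound 2 in one place: prop-1-en-1-yl in place of 1-bromoethyl on a carbonyl carbon. Within the data shown here, no step between measured compounds shows this particular change, so no measured guide exists. The expected step is a 2.5-fold higher number from compound 2 to compound 4 (0.40 log units; beyond the scatter), a small rise in the number, close to the edge of the scatter. Compound 4 is therefore estimated at 350 nM in this assay, expected to fall between 70 nM and 3000 nM.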

Compound 4, half-maximal inhibitory concentration: 55 nM
The estimate for compound 4 lay 6.4-fold (0.80 log units) above the measured number; the measured number lies below the stated range.
By their numbers in this assay, from the lowest: compound 4; then compound 2; then compound 3. At a limit, above all of these: compound 1.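

Putting prop-1-en-1-yl in place of 1-bromoethyl on the carbonyl carbon gives a 2.5-fold lower number from compound 2 to compound 4 (0.41 log units; beyond the scatter) in this assay, so a low number at this place does not depend on bromine. The step is modest, yet it is the first reading of any change at this place among the compounds shown. Nothing measured here gives a reason for the step. The compounds shown leave open how a plain propyl chain or an amine on this carbonyl carbon would read, so the part played by the double bond remains unknown.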